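Cyano for Dimethylamino on the Oxadiazole Aryl Group

This account rests on a few compounds, and the source may have more. Where it says the series, first, only, none or still open, it means among the compounds named here.

Compound 1 `CC(C)Cc1noc(C2CCc3c(nnn3C(C)(C)C)C2)n1` gives 66% in a functional assay on U2OS cells with metabotropic glutamate receptor 5 (Homo sapiens) as the target, read by calcium flux; on this read-out lower numbers stand for smaller maximal responses and higher numbers for larger maximal responses.
Compound 2 `CC(C)(C)n1nnc2c1CCC(c1nc(C3CCCCC3)no1)C2` gives 91% in this assay.
Compound 3 `CN(C)c1ccc(-c2noc(C3CCc4c(nnn4C(C)(C)C)C3)n2)cc1` gives 68% in this assay.

Compound 3 stands second highest of the three numbers. Its nearest neighbour is compound 1, with a number 2 percentage points higher from compound 1 to compound 3 (within the scatter), a step within the scatter. Compound 2 stands furthest away, with a number 23 percentage points lower from compound 2 to compound 3 (beyond the scatter). Compound 4 `CC(C)(C)n1nnc2c1CCC(c1nc(-c3ccc(C#N)cc3)no1)C2` differs from compound 3 in one place: cyano in place of dimethylamino on an aromatic carbon. Among the compounds with values here, no measured step exchanges one group for another on the six-membered aromatic ring of carbon only; the two steps that reach compound 3 replace the whole group on the aromatic carbon of the shared core, and only the step from cyclohexyl is beyond the scatter. The change from compound 3 to compound 4 keeps the phenyl ring and alters only its substituent, so a step no larger than the scatter is expected in this assay, and its direction cannot be read from the data. Compound 4 is therefore estimated at 72%, in the range 55% to 90%, which means an expected step of a number 4 percentage points higher from compound 3 to compound 4 (within the scatter).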

Compound 4, largest response reached (reported as percent of maximum), in percent of the reference or control that the assay uses: 87%
Compound 4: middle estimate off by 15 percentage points, on the low side; the range from low to high includes it.
By their numbers in this assay, from the lowest: compounds 1 and 3 (each within the scatter of the next); then compounds 4 and 2 (each within the scatter of the next).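

In this assay, within the data shown here, cyano in place of dimethylamino is the first exchange on the phenyl ring itself that can be read, and it gives a number 19 percentage points higher from compound 3 to compound 4 (beyond the scatter) so the group on that ring, and not only the presence of the ring, bears on the maximal response. The 4-cyanophenyl group also closes the gap to cyclohexyl, with a number 4 percentage points lower from compound 2 to compound 4 (within the scatter) and it stands clear of isobutyl, with a number 21 percentage points higher from compound 1 to compound 4 (beyond the scatter) so among these compounds a phenyl ring at this place does not by itself hold the number down. Nothing given here explains why the two phenyl substituents differ.

From the compounds shown here alone, it remains open where an unsubstituted phenyl group would fall relative to compound 3 and compound 4. Going by these compounds, how other groups on the ring, such as methoxy, chlorine or a carboxylic acid, would compare also remains open.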